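A Third Methoxy Group Added to the Core of Compound 2

The compounds below may be only part of what the source reports. "The series", "measured", "known", "first", "only" and "open" are said of these compounds alone.

Within the data shown here, compound 2 `COc1cc2c(cc1OC)CN(CCCCC(=O)c1c(C)c(OC)c(OC)c(OC)c1OC)CC2` is the only compound here with a numerical result: in an assay on membranes from brain for displacement of a labelled ligand from Sigma non-opioid intracellular receptor 1 (Cavia porcellus), read by scintillation counting, with a stated time of 120 min (a lower number here means a stronger inhibitor, a higher number a weaker inhibitor), compound 2 gives 160 nM. Compound 1 `COc1cc2c(c(OC)c1OC)CCN(CCC(=O)c1c(C)c(OC)c(OC)c(OC)c1OC)C2` carries a shorter chain between the ring nitrogen and the carbonyl and one more methoxy group on its core. In this assay, among the measured compounds shown here, compound 1 gives > 1000 nM, which is a limit of the assay and not a number. the limit of > 1000 nM in this assay, at which 1 of the 2 values shown sits. Compound 1 and compound 2 differ in two places, and their two values show only that one compound is weak while the other is measurable.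

Compound 3 `COc1cc2c(c(OC)c1OC)CCN(CCCCC(=O)c1c(C)c(OC)c(OC)c(OC)c1OC)C2` keeps the five-carbon chain of compound 2 and differs from it in one place: methoxy in place of hydrogen on an aromatic carbon. For the measured compounds named here, the added group is the one also present on compound 1, whose result stayed at the limit, but the shorter chain of compound 1 is not shared by compound 3, and no single step separates them. The expected step is a 2.8-fold higher number from compound 2 to compound 3 (0.45 log units; beyond the scatter), toward weaker binding, and of a size beyond the usual scatter. For compound 3 the estimate is 450 nM, within a range from 130 nM to 1600 nM.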

Compound 3, inhibition constant: > 1000 nM
Compound 3 ended at the assay's limit (the forecaster's own chance of this, stated with the estimate: 25%); at least 2.2-fold (0.34 log units) between middle value and limit.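

Among these compounds, the single change gives an at least 6.2-fold higher number from compound 2 to compound 3 (0.79 log units; beyond the scatter) in this assay, which ties a loss of binding to methoxy in place of hydrogen on this aromatic carbon, ortho to a methoxy group and ortho to a fused ring. Compound 3 gives > 1000 nM, which is a limit of the assay and not a number, so the step marks only the smallest size the loss can have. Compound 1 carries the same methoxy group but also a shorter chain, so its result could not separate those two changes, whereas here the added methoxy group alone is enough to reach the limit: the limit of > 1000 nM in this assay, at which 2 of the 3 values shown sit.

The compounds shown leave open whether the loss belongs to methoxy in particular or would also follow a hydroxyl group, a fluorine atom or a larger ethoxy group on this carbon. They also leave open whether a longer chain on the core of compound 3 would bring back a measurable value, and how far past the limit compound 3 truly lies.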